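This account rests on a few compounds, and the source may have more. Where it says the series, first, only, none or still open, it means among the compounds named here.

Of the compounds shown here, three sharing one core have been measured in a functional assay for inhibition, with Rattus norvegicus as the target; on this read-out higher numbers stand for weaker inhibition and lower numbers for stronger inhibition. Compound 1 `CC(=O)c1ccc(/N=c2\c(O)c(O)\c2=N/C(C)C(C)(C)C)cc1` gives 21200 nM. Compound 2 `CCCCCCC/N=c1\c(O)c(O)\c1=N/c1ccc(C#N)cc1` returns > 30000 nM, which is a limit of the assay and not a number. Compound 3 `Cc1cc(C#N)ccc1/N=c1\c(O)c(O)\c1=N/[C@H](C)C(C)(C)C` gives 1080 nM, the lower of the two actual numbers, and its gap to compound 1, the nearest value, lies beyond the scatter of repeated measurements.

Compound 4 `C[C@@H](/N=c1\c(O)c(O)\c1=N/c1ccc(C#N)cc1Cl)C(C)(C)C` has not yet been measured. It carries chloro in place of methyl on an aromatic carbon, and the counted difference is this: chloro in place of methyl on an aromatic carbon. Among the measured compounds shown here, no two measured compounds differ in only one place, so the data do not show directly what this swap does in this assay. The rest of the structure matches compound 3 at 1080 nM, so no change beyond the scatter is expected. The expected move is small: a 1.2-fold lower number from compound 3 to compound 4 (0.08 log units; within the scatter). For compound 4 the estimated value is 900 nM, with an expected range from 300 nM to 3000 nM.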

Compound 4, half-maximal inhibitory concentration: 41 nM
Beside the measured number, compound 4's estimate is 22-fold (1.34 log units) above it; the measured number lies below the stated range.
By their numbers in this assay, from the lowest: compound 4; then compound 3; then compound 1. At a limit, above all of these: compound 2.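

Chloro in place of methyl on an aromatic carbon gives a 26-fold lower number from compound 3 to compound 4 (1.42 log units; beyond the scatter) in this assay, a large step beyond the scatter. No other pair of compounds shown differs in only one place, so this is the first direct sign that this position, ortho to a large group and meta to a cyano group, strongly affects the read-out: the count of heavy atoms stays the same, and neither group carries hydrogen-bond donors or acceptors. No measured property shown here accounts for the size of this step.

Going by these compounds, whether fluoro, bromo or methoxy at this position would give a lower or a higher number stays open, as does the result with a plain hydrogen there. Also open, on these data alone, is whether the swap would have the same effect with a different group elsewhere in the structure.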